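Compound 1 to compound 4: added methyl on the benzyl group

The source may hold more compounds than are shown below. What is called first, only, known or untested is meant among the compounds shown, and "the series" means these compounds.

- compound 1 `Cc1ccc(S(=O)(=O)Oc2ccccc2/C=C(\C#N)C(=O)Nc2nnc(Cc3ccccc3)s2)cc1`: 15%
- compound 2 `COc1ccc(S(=O)(=O)Oc2ccccc2/C=C(\C#N)C(=O)Nc2nnc(Cc3ccccc3)s2)cc1`: 23%
- compound 3 `N#C/C(=C\c1ccccc1OS(=O)(=O)c1ccccc1[N+](=O)[O-])C(=O)Nc1nnc(Cc2ccccc2)s1`: 10%

These values come from an ADME assay on HEK-293T cells (Homo sapiens) for inhibition, read by CCK-8 assay, with a stated time of 48 h, tested at 20 uM; on this read-out lower numbers stand for less inhibition of growth and higher numbers for more inhibition of growth at the one concentration tested. Compound 1 stands within the scatter of both other compounds: the steps are a number 8 percentage points higher from compound 1 to compound 2 (within the scatter) and a number 5 percentage points lower from compound 1 to compound 3 (within the scatter). Going by the values given here, only one measured step exceeds the scatter, and it is modest: a number 13 percentage points lower from compound 2 to compound 3 (beyond the scatter).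

Compound 4 `Cc1ccc(Cc2nnc(NC(=O)/C(C#N)=C/c3ccccc3OS(=O)(=O)c3ccc(C)cc3)s2)cc1` is still to be measured. It carries methyl in place of hydrogen on an aromatic carbon of compound 1, para to a large group, which turns benzyl into 4-methylbenzyl: methyl in place of hydrogen on an aromatic carbon. Among the compounds with values here, no measured step changes the benzyl group, so the data give no direct read on this change. The nearest guide is the change of aromatic substituent in a number 8 percentage points higher from compound 1 to compound 2 (within the scatter), which stayed within the scatter. No step beyond the scatter is therefore expected in this assay, and no direction is favoured.

The expected step is a number 1 percentage points higher from compound 1 to compound 4 (within the scatter). For compound 4 the estimated value is 16%, with an expected range from 6% to 29%.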

Compound 4, percent growth inhibition at one concentration: 22%
For compound 4 the middle estimate is 6 percentage points below the measured one, within the range that was stated.
By their numbers in this assay, from the lowest: compounds 3, 1, 4 and 2 (each within the scatter of the next, the first and the last beyond it).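

In this assay, the first read on the benzyl end of the series is a number 7 percentage points higher from compound 1 to compound 4 (within the scatter), so one added methyl on this aromatic carbon, para to a large group, keeps compound 4 within the scatter of compound 1. Together with the earlier sulfonyl-side steps, this extends the measured changes to the far end of the core of compound 1, where 4-methylbenzyl in place of benzyl gives no step beyond the scatter. Nothing measured on these compounds speaks to the origin of this result.

Open is how an amine or a carboxylic acid at the same place on the benzyl group would read, as methyl is the only group shown there. Also open, as far as these compounds go, is whether 4-methylbenzyl would read the same alongside the 4-methoxyphenyl or 2-nitrophenyl groups on the sulfonyl sulfur.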